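Compound 4 and the top of the cytotoxicity scale

The source may report more compounds than this note shows. Statements on the series, on what has been measured and on what is new or still open speak of the compounds shown alone.

Measured in an ADME assay on MDCK cells (Canis lupus familiaris) for cytotoxicity, with a stated time of 24 h; a lower number here means that less compound is tolerated, a higher number that more compound is tolerated:
Compound 1 `CCC(CC)O[C@@H]1C=C(C(=O)Nc2ccccc2)C[C@H](N)[C@H]1NC(C)=O`: 151000 nM
Compound 2 `CCC(CC)O[C@@H]1C=C(C(=O)O)C[C@H](NC(=O)OC(C)(C)C)[C@H]1NC(C)=O`: > 1000000 nM (a limit, not a number)
Compound 3 `CCC(CC)O[C@@H]1C=C(C(=O)Nc2ccccc2OC)C[C@H](NC(=O)OC(C)(C)C)[C@H]1NC(C)=O`: > 1000000 nM (a limit, not a number)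

Compound 3 has no exact number, only the limit > 1000000 nM as its reading. Its place is at the top of the scale: the limit of > 1000000 nM in this assay, at which 2 of the 3 values shown sit. The change to compound 4 `CCC(CC)O[C@@H]1C=C(C(=O)Nc2ccccc2)C[C@H](NC(=O)OC(C)(C)C)[C@H]1NC(C)=O` is hydrogen in place of methoxy on an aromatic carbon, which is hydrogen in place of methoxy on an aromatic carbon, ortho to a large group. Among the measured compounds shown here, one measured step bears on this, a step that the two limits leave unreadable from compound 2 to compound 3, and it gives no size to carry over. No step beyond the usual scatter is therefore expected in this assay. The expected step is a number no higher from compound 3 to compound 4 (the limit leaves the size open), with no direction favoured. For compound 4 the estimate is 1000000 nM, with an expected range from 400000 nM to 2500000 nM, and a reading at the limit is likely.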

Compound 4, half-maximal cytotoxic concentration: > 1000000 nM
Compound 4 gave a limit, no number (the forecaster's own chance of this, stated with the estimate: 80%); the middle value lies on the limit itself.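

In this assay, tert-butoxycarbonyl in place of hydrogen on the amine nitrogen gives the first readable step: an at least 6.6-fold higher number from compound 1 to compound 4 (0.82 log units; beyond the scatter). Methoxy or hydrogen on the aromatic carbon makes no visible difference, and neither does anilino or hydroxy on the carbonyl carbon, but these steps cannot be read, as compound 2, compound 3 and compound 4 all stand at a limit rather than a number: the limit of > 1000000 nM in this assay, at which 3 of the 4 values shown sit.

Still open, from the compounds shown here alone, is whether an amine or a carboxylic acid on that aromatic carbon would bring a reading below the limit. Going by these compounds, whether a smaller acetyl group on the amine nitrogen would do so is also open.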